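The compounds below may be only part of what the source reports. "The series", "measured", "known", "first", "only" and "open" are said of these compounds alone.

Measured in a functional assay on cells (Leukemia cell, Homo sapiens) for inhibition; a higher number here means a weaker inhibitor of growth, a lower number a stronger inhibitor of growth:
- Compound 1 `Cc1cn2c(/C=N/NC(=N)N)c(-c3ccsc3)nc2s1`: 46800 nM
- Compound 2 `N=C(N)N/N=C/c1c(-c2cc(Cl)sc2Cl)nc2n1CCS2`: 24500 nM
- Compound 3 `N=C(N)N/N=C/c1c(-c2cccs2)nc2sccn12`: 38000 nM

The three compounds share the same side chain, but their cores and thiophene groups are not all alike. Compound 2 gives 24500 nM, and this value lies within the usual scatter of the other two, so the three cannot be ranked against one another.

Compound 4 `N=C(N)N/N=C/c1c(-c2cccs2)nc2n1CCS2` has not yet been measured. It keeps the core of compound 2 and differs at a single place: thiophen-2-yl in place of 2,5-dichlorothiophen-3-yl on an aromatic carbon. In words, thiophen-2-yl stands in place of 2,5-dichlorothiophen-3-yl on an aromatic carbon.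

For the measured compounds named here, no two measured compounds differ in one place only, so the data give no direct measure of this exchange. The closest guide is compound 3, which carries thiophen-2-yl on a different core and gives 38000 nM. The whole set also spans only a narrow range. A change beyond the scatter is therefore not expected, though the number may end up slightly higher. The estimated step is a 1.4-fold higher number from compound 2 to compound 4 (0.15 log units; within the scatter). For compound 4 the expected value is 35000 nM, with an estimated range from 20000 nM to 60000 nM.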

Compound 4, concentration for total growth inhibition: 38900 nM
Compound 4: the middle estimate sits 1.1-fold (0.05 log units) below what was measured; low and high end bracket the measured number.
By their numbers in this assay, from the lowest: compounds 2, 3, 4 and 1 (each within the scatter of the next).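

For the compounds shown here, this pair gives the first direct reading of a change at this aromatic carbon with the core held constant: in this assay, thiophen-2-yl in place of 2,5-dichlorothiophen-3-yl gives a 1.6-fold higher number from compound 2 to compound 4 (0.20 log units; within the scatter). The exchange removes the two chlorine atoms and also alters the point at which the thiophene is attached, yet the two compounds cannot be told apart in this assay, and this single pair cannot separate those two differences. No accompanying measurement bears on this result.

The compounds shown carry only thiophene groups at this position, so it remains open whether a phenyl ring, an amine or a carboxylic acid on the same aromatic carbon would give a number beyond the scatter. All four compounds also share the same side chain and lie within the scatter of their neighbours in the ranking, which leaves open what part that chain plays and which structural change, if any, could separate these compounds in this assay.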